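This account rests on a few compounds, and the source may have more. Where it says the series, first, only, none or still open, it means among the compounds named here.

Of the compounds shown here, two built on a shared core have been tested so far in a functional assay on Huh-5-2 cells (Homo sapiens), read by MTT assay; on this read-out lower numbers stand for higher toxicity in this test and higher numbers for lower toxicity in this test. Compound 1 `NC(=O)c1ccc(-c2ccc(Cl)cc2COc2ccc(-c3nc4cc(C(=O)O)ccc4n3C3CCCCC3)cc2)cc1` gives > 50000 nM, which is a limit of the assay and not a number. Within the data shown here, compound 2 `CC(=O)c1ccc(-c2ccc(Cl)cc2)c(COc2ccc(-c3nc4cc(C(=O)O)ccc4n3C3CCCCC3)cc2)c1` gives 24000 nM, the only actual number available, so it is the single firm reference point here.

Compound 3 `O=C(O)c1ccc2c(c1)nc(-c1ccc(OCc3cc(C(=O)NCc4ccccc4)ccc3-c3ccc(Cl)cc3)cc1)n2C1CCCCC1` has not yet been measured. It differs from compound 2 in one place: benzylamino in place of methyl on a carbonyl carbon. Put in words, this is benzylamino in place of methyl on a carbonyl carbon, which turns acetyl to benzylcarbamoyl. Among the measured compounds shown here, no measured pair shows what this exchange does, so the expectation is a cautious one. It rests on compound 2 at 24000 nM, and the change is not expected to move the reading in a clear direction. The estimated step of a 1.0-fold higher number from compound 2 to compound 3 (0.02 log units; within the scatter) is small and stays within the usual scatter of this assay. Compound 3 might also return only a limit, as compound 1 did. The expected value for compound 3 is 25000 nM, with an estimated range from 10000 nM to 50000 nM.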

Compound 3, half-maximal cytotoxic concentration: 22000 nM
Compound 3: middle estimate off by 1.1-fold (0.06 log units), on the high side; measured number inside the range.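

Replacing methyl with benzylamino on a carbonyl carbon, which turns acetyl to benzylcarbamoyl, gives a 1.1-fold lower number from compound 2 to compound 3 (0.04 log units; within the scatter) in this assay. Among these compounds, this is the first direct reading of a change at this position, and it shows that a group of 8 heavy atoms, with an aromatic ring and a hydrogen-bond donor, can replace a single carbon with no change that can be claimed in this test. Compound 1 gives a limit of the assay and not a number: the limit of > 50000 nM in this assay, at which 1 of the 3 values shown sits.

Among the compounds shown here, compound 1 also differs from the other two compounds in more than one place, so it offers no step that can be read, and this single pair cannot establish a trend for the position. On these data alone, it remains open whether a plain amino group, a hydroxyl group forming a carboxylic acid, or a longer chain such as phenethylamino on this carbonyl carbon would also leave the reading unchanged.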